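The source may report more compounds than this note shows. Statements on the series, on what has been measured and on what is new or still open speak of the compounds shown alone.

Series notes, values in a physicochemical assay for solubility; a lower number here means a less soluble compound, a higher number a more soluble compound:

- Compound 1 `CN(C)CCNc1ccnc2cc(OCc3ccc(F)cc3)ccc12`: > 10000 ug/mL, a limit.
- Compound 2 `CN(C)CCNc1ccnc2cc(OCc3ccccc3)ccc12`: > 10000 ug/mL, a limit.
- Compound 3 `CN(C)CCCNc1ccnc2cc(OCc3ccc(F)cc3)ccc12`: > 10000 ug/mL, a limit.

Compound 2 has no numerical value, only the limit of > 10000 ug/mL. The other two compounds give limits as well, and the record is the limit of > 10000 ug/mL in this assay, at which 3 of the 3 values shown sit. No ranking within the series can be read from these results.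

The next compound is compound 4 `CCOc1ccc2c(NCCN(C)C)ccnc2c1`, still unmeasured. It carries methyl in place of phenyl on a saturated chain carbon bound to an oxygen on an aromatic ring, so benzyloxy becomes ethoxy: methyl in place of phenyl on a saturated chain carbon bound to an oxygen on an aromatic ring.

Going by the values given here, two measured steps bear on this only loosely: a step that the two limits leave unreadable from compound 1 to compound 2, and a step that the two limits leave unreadable from compound 1 to compound 3. Neither has a readable size, and neither removes the phenyl, so they offer no measured size or direction for this change.

The expectation therefore rests on compound 2 at > 10000 ug/mL, which is a limit. In this assay, the expected result is a step that the limit leaves unreadable from compound 2 to compound 4, with no direction supported by the data. A further limit is the most likely report. For compound 4, the estimated value is 12000 ug/mL, with an expected range of 6000 ug/mL to 25000 ug/mL.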

Compound 4, solubility: > 10000 ug/mL
Compound 4: a limit, no number; the forecaster's own chance of this, stated with the estimate: 85%; the middle value does not contradict the limit.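

In this assay compound 4 gives > 10000 ug/mL as a limit. Going by these compounds alone, no step to compound 4 can be read, neither from compound 2 nor from compound 1, and the record is a single shared limit: the limit of > 10000 ug/mL in this assay, at which 4 of the 4 values shown sit.

The compounds shown leave open how far each lies beyond that limit, and whether changing benzyloxy to ethoxy moves the read-out in this assay at all.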